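This account rests on a few compounds, and the source may have more. Where it says the series, first, only, none or still open, it means among the compounds named here.

Series notes, cytotoxicity. Going by the values given here, compound 2 `COC(=O)c1sc2ccccc2c1C#Cc1ccccc1` gives the lowest of the two numbers so far in a functional assay on cells (CNS cell, Homo sapiens) for cytotoxicity, read by sulforhodamine B assay, with a stated time of 48 h (a higher number here means a weaker inhibitor of growth, a lower number a stronger inhibitor of growth), at 58900 nM. Its nearest neighbour is compound 1 `COC(=O)c1sc2ccccc2c1C#Cc1ccc(OC)cc1`, which in this assay gives 103000 nM; the step of a 1.7-fold lower number from compound 1 to compound 2 (0.24 log units; within the scatter) separates them, so the two values cannot be ordered on these data. Compound 3 `COC(=O)c1sc2ccccc2c1C#Cc1ccc(F)cc1` is the next member awaiting a number; it differs from compound 2 by fluoro in place of hydrogen on an aromatic carbon. Among the compounds with values here, the only measured step that bears on this change is the one from compound 1 to compound 2, which also alters a single substituent on an aromatic carbon of the same ring and stays within the scatter. Within the data shown here, no step involving fluoro exists. The expectation for this assay is therefore a step of no clear size in either direction, and compound 3 is estimated at 65000 nM (range 25000 nM to 160000 nM), with the expected step from compound 2 being a 1.1-fold higher number from compound 2 to compound 3 (0.04 log units; within the scatter).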

Compound 3, concentration for 50% growth inhibition: 56200 nM
For compound 3 the middle estimate is 1.2-fold (0.06 log units) above the measured one; the range from low to high includes it.
By their numbers in this assay, from the lowest: compounds 3, 2 and 1 (each within the scatter of the next).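

In this assay, going by these compounds alone, the phenyl to 4-fluorophenyl change gives a 1.0-fold lower number from compound 2 to compound 3 (0.02 log units; within the scatter) and adds a first halogen to this position, para to a large group, with no step that can be told from the scatter. Fluoro in place of methoxy at that position gives a 1.8-fold lower number from compound 1 to compound 3 (0.26 log units; within the scatter) and is also within the scatter, so hydrogen, fluoro and methoxy here form a set of three that cannot be ordered, and the position has so far shown no response to any of these substituents. No measurement on hand offers an explanation of this result.

Still open, on these data alone, is whether an amine or a carboxylic acid at this position would give a step beyond the scatter. Also open, as far as these compounds go, is whether a change away from this ring, such as a carboxylic acid in place of the methyl ester on the shared core, would shift the number.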